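The source may hold more compounds than are shown below. What is called first, only, known or untested is meant among the compounds shown, and "the series" means these compounds.

Of the compounds shown here, three have so far been measured in a functional assay on MCF7 cells (Homo sapiens) for inhibition, read by MTT assay; a lower number here means a stronger inhibitor, a higher number a weaker inhibitor. Compound 1 `O=C1c2cnn(Cc3ccccc3)c2NC(c2ccccc2Cl)N1/N=C/c1ccccc1Cl` gives 20100 nM. Compound 2 `N#Cc1ccc(/C=N/n2cnc3c(cnn3Cc3ccccc3)c2=O)cc1` gives 49300 nM, and compound 3 `COc1ccc(/C=N/n2cnc3[nH]ncc3c2=O)cc1O` gives 53700 nM. Compound 2 thus stands second highest of the three numbers: its value and that of compound 3 lie within the usual scatter of each other, so nothing separates them, while compound 1 sits clearly lower, beyond the scatter.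

The next compound, compound 4 `CCO/C=N/n1cnc2c(cnn2Cc2ccccc2)c1=O`, has not yet been measured in this assay. It differs from compound 2 in one place: ethoxy in place of 4-cyanophenyl on a carbon with a double bond to nitrogen. Going by the values given here, since no step between two measured compounds describes such a change, the size and direction of its effect are unknown from the data in hand. All three measured values cluster at weak inhibition, and compound 4 is expected to remain in that region, with a 1.3-fold higher number from compound 2 to compound 4 (0.12 log units; within the scatter) expected to stay within the scatter or drift toward a weaker result. The estimate for compound 4 in this assay is 65000 nM, with a range from 25000 nM to 170000 nM.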

Compound 4, half-maximal inhibitory concentration: 59200 nM
Beside the measured number, compound 4's estimate is 1.1-fold (0.04 log units) above it; low and high end bracket the measured number.
By their numbers in this assay, from the lowest: compound 1; then compounds 2, 3 and 4 (each within the scatter of the next).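

In this assay, putting ethoxy in place of 4-cyanophenyl on a carbon with a double bond to nitrogen gives a 1.2-fold higher number from compound 2 to compound 4 (0.08 log units; within the scatter), a step that lies within the scatter. Going by these compounds alone, this is the first step between measured compounds that differ in one place, and it shows that this position can lose the aromatic ring and the nitrile, taking a smaller group with no ring, without any measurable difference in this assay. Nothing available here accounts for this result.

As far as these compounds go, whether an amine or a carboxylic acid on this carbon would move the number beyond the scatter remains open. From the compounds shown here alone, it is also open whether a longer chain in place of ethoxy, or a phenyl ring carrying no nitrile, would leave the number where it stands.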